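This account rests on a few compounds, and the source may have more. Where it says the series, first, only, none or still open, it means among the compounds named here.

Measured compounds in a functional assay on A549 cells (Homo sapiens) for cytotoxicity, read by MTT assay, with a stated time of 24 h; a higher number here means a weaker inhibitor, a lower number a stronger inhibitor:
Compound 1 `C=CC1=C(C(=O)NCCCCC)C(c2ccc(Cl)c(Cl)c2)OC1` gives > 100000 nM, a limit of the assay.
Compound 2 `C=CC1=C(C(=O)NCc2ccc(Cl)cc2)C(c2ccc(F)cc2)OC1` gives > 100000 nM, also a limit.
Compound 3 `C=CC1=C(C(=O)NCC(C)C)C(c2ccc(OC)cc2)OC1` gives > 100000 nM, again a limit.

Compound 1 therefore stands at the limit rather than at a number in this assay; its value cannot be ordered against the other two, and the limit of > 100000 nM in this assay, at which 3 of the 3 values shown sit, is the whole of what the series shows so far. Among the compounds with values here, no pair of measured compounds differs in one place, so no measured step gives a size for any single change.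

Compound 4 `C=CC1=C(C(=O)NCc2ccccc2)C(c2ccc(Cl)c(Cl)c2)OC1` is not yet measured in this assay. It differs from compound 1 by phenyl in place of butyl on a saturated chain carbon bound to an amide-type nitrogen, which read one bond further out is pentylamino to benzylamino. A benzyl-type amide is already present in compound 2, which sits at the limit. The pentyl amide of compound 1 sits at the limit as well. On that basis the change is not expected to move the value beyond the scatter, and the most likely outcome is that compound 4 too is reported only as a limit in this assay. The step this estimate implies, a step that the limit leaves unreadable from compound 1 to compound 4, is expected to be none beyond the scatter. Compound 4 is estimated at 150000 nM, with a range from 50000 nM to 500000 nM.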

Compound 4, half-maximal inhibitory concentration: > 100000 nM
Compound 4 ended at the assay's limit; the forecaster's own chance of this, stated with the estimate: 85%; the middle value lies beyond the limit too.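

Compound 1 and compound 4 both sit at a limit in this assay, so no size can be read for phenyl in place of butyl on a saturated chain carbon bound to an amide-type nitrogen. The compounds shown leave open which structural change, if any, would bring a value inside the measurable range of this assay: the limit of > 100000 nM in this assay, at which 4 of the 4 values shown sit.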